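A few compounds are considered here, and "the series" means these few. Any claim that something is new, unique, unknown or untested is made for them only; others in the source may bear on it.

Measured so far:
- compound 1 `COc1ccc2c(=O)c(/C=C/C(=O)Nc3ccccc3)coc2c1` — in a functional assay on A549 cells (Homo sapiens) for inhibition, read by MTT assay, with a stated time of 48 h (on this read-out lower numbers stand for stronger inhibition and higher numbers for weaker inhibition), compound 1 gives 51000 nM
- compound 2 `COc1ccc(NC(=O)/C=C/c2coc3cc(O)ccc3c2=O)cc1` — in this assay compound 2 gives 12800 nM

Among the compounds with values here, compound 2 has the lower of the two numbers so far; the number for compound 1 sits well above it, a gap beyond the usual scatter. Compound 3 `O=C(/C=C/c1coc2cc(O)ccc2c1=O)Nc1ccccc1` is not yet measured. It differs from compound 2 in one place: hydrogen in place of methoxy on an aromatic carbon. Within the data shown here, no pair of measured compounds differs by exactly this change, so the size of the step in this assay cannot be read off directly; compound 1 carries the same unsubstituted phenyl but differs at the core as well, so its number is not a clean guide. With the modest support of the series, a small loss is expected, of the order of a 1.7-fold higher number from compound 2 to compound 3 (0.24 log units; within the scatter), though a result within the scatter would not surprise. Compound 3 is therefore expected near 22000 nM, within a range of 8000 nM to 60000 nM.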

Compound 3, half-maximal inhibitory concentration: 24400 nM
For compound 3 the middle estimate is 1.1-fold (0.04 log units) below the measured one, and the stated range covers the measured number.
By their numbers in this assay, from the lowest: compounds 2 and 3 (each within the scatter of the next); then compound 1.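

In this assay, hydrogen in place of methoxy on the aromatic carbon para to a large group, the change from 4-methoxyphenyl to phenyl, gives a 1.9-fold higher number from compound 2 to compound 3 (0.28 log units; within the scatter), so this read-out does not separate the two groups at this position. Within the data shown here, with the phenyl held constant, hydrogen in place of methyl on the oxygen of the core gives a 2.1-fold lower number from compound 1 to compound 3 (0.32 log units; beyond the scatter), a modest step, and the only single-place step here that lies beyond the scatter. Nothing measured here bears on the cause of either step.

As far as these compounds go, whether an amine or a carboxylic acid on the same aromatic carbon would give a step beyond the scatter stays open. So does the effect of a longer chain on the oxygen of the core.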